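This account rests on a few compounds, and the source may have more. Where it says the series, first, only, none or still open, it means among the compounds named here.

Compound 1, `Cc1ccccc1S(=O)(=O)c1ccc(CNC(=O)c2cc3cnccc3[nH]2)cc1`, gives 12 nM in an assay for inhibition of Nicotinamide phosphoribosyltransferase (Homo sapiens), read by mass spectrometry, with stated times of 15 min and 30 min; a higher number here means a weaker inhibitor, a lower number a stronger inhibitor.
Compound 2, `O=C(NCc1ccc(S(=O)(=O)N2CCCCC2)cc1)c1cc2ccncc2[nH]1`, gives 1000 nM in this assay.

Of the two measured compounds, compound 2 stands at the highest number, so it is the weaker inhibitor of the pair; its nearest neighbour is compound 1, whose number is far lower, a gap well beyond the scatter of repeated measurements. Compound 3, `O=C(NCc1ccc(S(=O)(=O)N2CCCCC2)cc1)c1cc2ccncc2o1`, has not yet been measured. It is derived from compound 2 by one change: a group of 9 heavy atoms (7 carbon, 1 nitrogen, 1 oxygen; one five-membered aromatic ring with 1 hetero atom, one six-membered aromatic ring with 1 hetero atom) in place of a group of 9 heavy atoms (7 carbon, 2 nitrogen; one five-membered aromatic ring with 1 hetero atom, one six-membered aromatic ring with 1 hetero atom), on a carbonyl carbon. Within the data shown here, no measured pair shows this same change, so the size of the step cannot be read from the numbers at hand. The step of a 2.5-fold higher number from compound 2 to compound 3 (0.40 log units; beyond the scatter) is expected to be a modest move towards a higher number, that is a somewhat weaker inhibitor, though it may also end up within the scatter. For compound 3 the estimated value in this assay is 2500 nM, with a range from 800 nM to 8000 nM.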

Compound 3, half-maximal inhibitory concentration: 40 nM
Estimate against measurement, compound 3: 63-fold (1.80 log units) above, and the stated range ends above it.
By their numbers in this assay, from the lowest: compound 1; then compound 3; then compound 2.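

Exchanging the group on the carbonyl carbon gives a 25-fold lower number from compound 2 to compound 3 (1.40 log units; beyond the scatter) in this assay, a large step and the first sign that this place is highly sensitive to what sits there. The two groups have the same count of 9 heavy atoms and the same two aromatic rings, yet the one that leaves has 7 carbon and 2 nitrogen atoms with 1 hydrogen-bond donor and 1 hydrogen-bond acceptor, while the one that enters has 7 carbon, 1 nitrogen and 1 oxygen atom with 0 hydrogen-bond donors and 2 hydrogen-bond acceptors, so a hydrogen-bond donor in this group is not needed for compound 3 to reach its low number. Nothing at hand explains why so small a change in atoms brings so large a step.

As far as these compounds go, whether the same exchange would bring a step of similar size on the core of compound 1 stays open, since a single pair shows this change. From the compounds shown here alone, it is also open how a sulfur atom in place of this oxygen, or a methyl group on the nitrogen that carries the hydrogen in compound 2, would fare at this place.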